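Pyridin-3-yl in Place of 3-Methylphenyl on the Core

The compounds below may be only part of what the source reports. "The series", "measured", "known", "first", "only" and "open" are said of these compounds alone.

Measured compounds:
Compound 1 `Cc1cccc(-c2nc(C(F)(F)F)n(CC[C@@H](O)C[C@@H](O)CC(=O)O)c2-c2ccc(F)cc2)c1`: 29 nM
Compound 2 `Cc1ccc(-c2nc(C(F)(F)F)n(CC[C@@H](O)C[C@@H](O)CC(=O)O)c2-c2ccc(F)cc2)cc1`: 43 nM
Compound 3 `COc1ccc(-c2nc(C(F)(F)F)n(CC[C@@H](O)C[C@@H](O)CC(=O)O)c2-c2ccc(F)cc2)cc1`: 68 nM

All three compounds were tested in an assay on microsomes from liver for inhibition of 3-hydroxy-3-methylglutaryl-coenzyme A reductase (Rattus norvegicus); on this read-out lower numbers stand for stronger inhibition and higher numbers for weaker inhibition. Compound 1 gives 29 nM, the lowest of the three numbers. The nearest is compound 2, reached by a 1.5-fold higher number from compound 1 to compound 2 (0.17 log units; within the scatter), a step that stays within the scatter; the furthest is compound 3, reached by a 2.3-fold higher number from compound 1 to compound 3 (0.37 log units; beyond the scatter), a modest step beyond it. Between compound 2 and compound 3 there is a 1.6-fold higher number from compound 2 to compound 3 (0.20 log units; within the scatter), again within the scatter.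

Compound 4 `O=C(O)C[C@H](O)C[C@H](O)CCn1c(C(F)(F)F)nc(-c2cccnc2)c1-c1ccc(F)cc1` has not yet been measured. Relative to compound 1 it carries pyridin-3-yl in place of 3-methylphenyl on an aromatic carbon.

Within the data shown here, none of the measured steps replaces the ring itself: each only moves or swaps a substituent on the phenyl, and those moves range from inside the scatter to a modest loss. A change to a ring with one hetero atom is therefore not covered by the data, and the expectation rests on the observation that the shared core has so far tolerated small changes at this position. A small loss or no change beyond the scatter is expected, with a 1.6-fold higher number from compound 1 to compound 4 (0.19 log units; within the scatter). Compound 4 is expected to give about 45 nM, within a range from 15 nM to 140 nM.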

Compound 4, half-maximal inhibitory concentration: 66 nM
Compound 4: the middle estimate sits 1.5-fold (0.17 log units) below what was measured; low and high end bracket the measured number.
By their numbers in this assay, from the lowest: compounds 1, 2, 4 and 3 (each within the scatter of the next, the first and the last beyond it).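

In this assay, the phenyl ring itself can be exchanged at this position, which the earlier substituent moves could not show: pyridin-3-yl in place of 3-methylphenyl gives a 2.3-fold higher number from compound 1 to compound 4 (0.36 log units; beyond the scatter), a modest loss that leaves the number within the range already seen for the series. Set against the other two groups, the new ring stands apart from neither, with a 1.5-fold higher number from compound 2 to compound 4 (0.19 log units; within the scatter) and a 1.0-fold lower number from compound 3 to compound 4 (0.01 log units; within the scatter), both within the scatter, so on this read-out pyridin-3-yl cannot be told from 4-methylphenyl or 4-methoxyphenyl, and only compound 1 lies beyond the scatter from it. Nothing measured here gives a reason for these numbers.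

Going by these compounds, what pyridin-2-yl or pyridin-4-yl would give at this position remains open, so a single ring with one nitrogen cannot say whether the place of that nitrogen matters. Equally open, on these data alone, is whether a methyl group on the pyridin-3-yl ring, or an amine or a carboxylic acid on the ring at this position, would bring the number back towards that of compound 1 or move it further away.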